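Inverting a ring stereocentre in a bromofuranone acetate

The source may hold more compounds than are shown below. What is called first, only, known or untested is meant among the compounds shown, and "the series" means these compounds.

Compound 1, `CCC[C@@H](OC(C)=O)C1=C(Br)[C@@](C)(OC)OC1=O`, is the reference point of this small set. Within the data shown here, in a functional assay on KB cells (Homo sapiens) for cytotoxicity (on this read-out lower numbers stand for an effect already at smaller amounts and higher numbers for an effect only at larger amounts of compound), compound 1 gives 2.8 ug/mL, the lowest of the two numbers measured so far. Among the measured compounds shown here, its only measured neighbour is compound 2, `CCC[C@@H](OC(C)=O)C1=C(Br)[C@@](CI)(OC)OC1=O`, which in this assay gives 7.1 ug/mL; the step from compound 1 to compound 2 is a 2.5-fold higher number from compound 1 to compound 2 (0.40 log units; beyond the scatter), and it comes from the iodo in place of hydrogen on a saturated chain carbon bound to a saturated ring carbon.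

Compound 3, `CCC[C@@H](OC(C)=O)C1=C(Br)[C@](C)(OC)OC1=O`, carries no added or removed atoms relative to compound 1: the two compounds have the same atoms and bonds and differ only in configuration as drawn: 1 of 2 stereo elements differ; a stereocentre at a saturated ring carbon is drawn S in compound 1 and R in compound 3. For the measured compounds named here, no measured step in this set bears on such a change of configuration, since the single step from compound 1 to compound 2 concerns an added halogen and says nothing about how this assay answers to an inverted stereocentre. The direction of any effect is therefore open, and the expectation rests on compound 1 alone.

Compound 3 is expected to give about 3.5 ug/mL in this assay, within a range from 1.2 ug/mL to 12 ug/mL. This estimate corresponds to an expected step of a 1.3-fold higher number from compound 1 to compound 3 (0.10 log units; within the scatter), which is not expected to go beyond the scatter, though the width of the range reflects the lack of any measured guide.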

Compound 3, concentration for half-maximal effect: 4.7 ug/mL
Estimate against measurement, compound 3: 1.3-fold (0.13 log units) below; low and high end bracket the measured number.
By their numbers in this assay, from the lowest: compounds 1, 3 and 2 (each within the scatter of the next, the first and the last beyond it).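

Inverting the stereocentre at a saturated ring carbon, from S as drawn to R, amounts to a 1.7-fold higher number from compound 1 to compound 3 (0.22 log units; within the scatter) in this assay. Among these compounds, this gives the first direct reading of configuration at this position, and it is a clean one, as no other change in the structures can account for the result: the fact that compounds 1 and 3 differ only in the configuration as drawn. The two drawn configurations at this ring carbon are therefore not separated by this read-out, whereas the earlier step, iodo in place of hydrogen on a saturated chain carbon bound to a saturated ring carbon, involved an added atom and gave no information about configuration.

On these data alone, whether the second stereo element, which is the same in compound 1 and compound 3, would prove equally indifferent to inversion remains open, as does whether the R configuration would behave the same way with iodo present. As far as these compounds go, how this assay would respond to an amine or a carboxylic acid in place of the acetate also remains open.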